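The source may hold more compounds than are shown below. What is called first, only, known or untested is meant among the compounds shown, and "the series" means these compounds.

Measured compounds in an assay on CHO cells for agonist activity at Neuronal acetylcholine receptor; alpha3/alpha6/beta2/beta3 (Homo sapiens), read by FLIPR and calcium flux; a higher number here means a larger maximal response, a lower number a smaller maximal response:

- compound 1 `CC(=O)N1CC2CC(C1)N2`: compound 1 gives 100%
- compound 2 `CC(C)C(=O)N1CC2CC(C1)N2`: compound 2 gives 45%
- compound 3 `O=C([C@H]1C[C@H]1F)N1CC2CC(C1)N2`: compound 3 gives 130%

Compound 3 stands highest of the three numbers in this assay; the nearest is compound 1, a number 30 percentage points higher from compound 1 to compound 3 (beyond the scatter), and the furthest is compound 2, a number 85 percentage points higher from compound 2 to compound 3 (beyond the scatter). The third measured step, a number 55 percentage points lower from compound 1 to compound 2 (beyond the scatter), also concerns the group on the carbonyl carbon.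

Compound 4 `O=C([C@@H]1C[C@@H]1F)N1CC2CC(C1)N2` differs from compound 3 as follows: the two compounds have the same atoms and bonds; at least one stereo element is drawn with a configuration in one of them and without one in the other: 2 of 4 stereo elements differ; a stereocentre at a saturated ring carbon is drawn R in compound 3 and S in compound 4; a stereocentre at a saturated ring carbon is drawn R in compound 3 and S in compound 4.

None of the three measured steps involves a change of configuration; all three exchange one group for another on the carbonyl carbon, so they do not set a direction or size for the step from compound 3 to compound 4. The measured range of the series, from compound 2 to compound 3, shows how wide the maximal response can swing within this core. A step of some size in this assay is therefore plausible in either direction, with a downward move considered somewhat more likely since compound 3 is the highest number seen, but the expectation is uncertain. The estimate for compound 4 is 95%, within 40% to 140%, which means an expected step of a number 35 percentage points lower from compound 3 to compound 4 (beyond the scatter).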

Compound 4, largest response reached (Emax), in percent of the reference or control that the assay uses: 120%
For compound 4 the middle estimate is 25 percentage points below the measured one; low and high end bracket the measured number.
By their numbers in this assay, from the lowest: compound 2; then compound 1; then compounds 4 and 3 (each within the scatter of the next).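

In this assay, reversing the drawn configuration of the 2-fluorocyclopropyl group gives a number 10 percentage points lower from compound 3 to compound 4 (within the scatter), so the maximal response at this position does not separate these two drawn forms. With the configuration of compound 4, the 2-fluorocyclopropyl group also stands clear of the isopropyl and methyl groups, with a number 75 percentage points higher from compound 2 to compound 4 (beyond the scatter) and a number 20 percentage points higher from compound 1 to compound 4 (beyond the scatter), so this group's edge over both does not rest on the configuration of compound 3 alone. The reading of the configuration change carries one reservation: the fact that one of compounds 3 and 4 is drawn with a defined configuration and the other without, at the place where they differ.

Left open is how a plain cyclopropyl or a trifluoromethyl group on the carbonyl carbon would compare, so the contributions of the ring and of the fluorine cannot yet be separated. The values shown also describe maximal response only and say nothing about potency.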